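Sulfonyl substituent change on the piperidine-carboxamide series

The compounds below may be only part of what the source reports. "The series", "measured", "known", "first", "only" and "open" are said of these compounds alone.

Within the data shown here, compound 1 `CCC(CC)S(=O)(=O)c1ccc(S(=O)(=O)N2CCC[C@@H](C(=O)N3CCC(F)(F)CC3)C2)cc1` is the stronger of the two measured members in a functional assay on BXPC-3 cells (Homo sapiens) for inhibition, read by MTT assay, with a stated time of 7 days (a lower number here means a stronger inhibitor, a higher number a weaker inhibitor), giving 40 nM. Among the measured compounds shown here, compound 2 `CCN(CC)S(=O)(=O)c1ccc(S(=O)(=O)N2CCC[C@@H](C(=O)N3CCS(=O)(=O)CC3)C2)cc1` gives 4430 nM in the same assay; since it differs from compound 1 in more than one place, no single step is defined between them, and their two values are all that can be said of the pair.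

Compound 3 `CC(C)NS(=O)(=O)c1ccc(S(=O)(=O)N2CCC[C@@H](C(=O)N3CCC(F)(F)CC3)C2)cc1` has not yet been measured. It differs from compound 1 in one place: isopropylamino in place of pentan-3-yl on a sulfonyl sulfur. This is a change of the group on the sulfonyl sulfur only; the rest of the shared core, including the amide and its 4,4-difluoropiperidine partner, is unchanged.

For the measured compounds named here, no measured pair isolates this change, so its effect cannot be read from the data. The expectation is a modest weakening, with the step from compound 1 to compound 3 estimated at a 3.8-fold higher number from compound 1 to compound 3 (0.57 log units; beyond the scatter), possibly no more than the usual scatter. Compound 3 is therefore estimated to give 150 nM in this assay, within a range of 40 nM to 600 nM.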

Compound 3, half-maximal inhibitory concentration: 470 nM
Compound 3: middle estimate off by 3.1-fold (0.50 log units), on the low side, and the stated range covers the measured number.
By their numbers in this assay, from the lowest: compound 1; then compound 3; then compound 2.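

In this assay, among these compounds, the group on the sulfonyl sulfur proves to matter on its own: with the rest of the shared core, including the amide and its 4,4-difluoropiperidine partner, held as in compound 1, isopropylamino in place of pentan-3-yl gives a 12-fold higher number from compound 1 to compound 3 (1.07 log units; beyond the scatter) as the first single-place change that can be read. The two groups differ in more than one respect, as isopropylamino brings a nitrogen and a hydrogen-bond donor that pentan-3-yl lacks and is also the smaller by heavy atoms, and this single step does not separate those differences. No measurement at hand accounts for the size of the step.

Still open, on these data alone, is whether the step follows the nitrogen or the smaller group, a question that isopropyl or cyclopentyl attached directly to the sulfonyl sulfur would help to settle. Also open, as far as these compounds go, is whether a step of this size would hold with another amide partner, such as morpholine, in place of 4,4-difluoropiperidine.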